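The source may hold more compounds than are shown below. What is called first, only, known or untested is meant among the compounds shown, and "the series" means these compounds.

Measured so far:
Compound 1, `COc1cc(/C=C\c2ccc(C(C)(C)C)cc2)cc(OC)c1OC`: 1.02 uM
Compound 2, `COc1cc(/C=C\c2ccc(SC)cc2)cc(OC)c1OC`: 1.9 uM

Among the measured compounds shown here, in a functional assay on A549 cells (Homo sapiens) for cytotoxicity (a higher number here means that more compound is needed for the effect, a lower number that less compound is needed), compound 2 has the higher of the two numbers, and the one step between them, a 1.9-fold higher number from compound 1 to compound 2 (0.27 log units; within the scatter), lies within the scatter. Compound 3, `COc1cc(/C=C/c2ccc(SC)cc2)cc(OC)c1OC`, differs from compound 2 in that (the two compounds have the same atoms and bonds and differ only in configuration as drawn: 1 of 1 stereo elements differ; a double bond is drawn Z in compound 2 and E in compound 3). For the measured compounds named here, no measured step changes the double-bond geometry, so nothing measured here bears directly on this change and its size and direction remain open. With that gap, the expected step of a 4.2-fold higher number from compound 2 to compound 3 (0.62 log units; beyond the scatter) is set broad. Compound 3 is estimated at 8 uM, within 1.5 uM to 50 uM.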

Compound 3, concentration for half-maximal effect: 4.7 uM
The estimate for compound 3 lay 1.7-fold (0.23 log units) above the measured number, and the stated range covers the measured number.
By their numbers in this assay, from the lowest: compounds 1 and 2 (each within the scatter of the next); then compound 3.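

In this assay, turning the double bond from Z to E gives a 2.5-fold higher number from compound 2 to compound 3 (0.39 log units; beyond the scatter), so the E form needs more compound for the effect. The earlier swap of tert-butyl for methylsulfanyl stayed within the scatter, making this the first step shown to exceed it. The shift can be assigned to the double-bond geometry alone, because nothing else changes: the fact that compounds 2 and 3 differ only in the configuration as drawn.

Among the compounds shown, only the methylsulfanyl pair has both geometries, so whether the same step holds with tert-butyl remains open. On these data alone, how an amine or a carboxylic acid at that place would behave also remains open.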